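This account rests on a few compounds, and the source may have more. Where it says the series, first, only, none or still open, it means among the compounds named here.

Compound 1 `CCn1c(=S)[nH]c2c(cc(-c3ccc(C)cc3)n2-c2ccccc2)c1=N`: 60%
Compound 2 `CCn1c(=S)[nH]c2c(cc(-c3ccc(Br)cc3)n2-c2ccccc2)c1=N`: 80%

Going by the values given here, in a functional assay on the whole organism for inhibition, with Rattus norvegicus as the target, read by ELISA, with stated times of 30 min and 6 h, at a dose of 30 mg/kg by the oral route (on this read-out higher numbers stand for more inhibition at the one dose given (going by the name of the read-out) and lower numbers for less inhibition), compound 1 gives 60%, the lower of the two numbers; compound 2 gives 80%, so a number 20 percentage points higher from compound 1 to compound 2 (beyond the scatter) is the one measured step, and it concerns the aryl group only. Compound 3 `Cc1ccc(-c2cc3c(=N)n(N)c(=S)[nH]c3n2-c2ccccc2)cc1` differs from compound 1 by amino in place of ethyl on an aromatic nitrogen. Among the compounds with values here, no measured step touches this aromatic nitrogen, so there is nothing to anchor a direction; in this assay no change beyond the scatter is expected. Compound 3 is expected to show no change at the digits printed from compound 1 to compound 3 (within the scatter). Compound 3 is therefore estimated at 60%, ranging from 35% to 80%.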

Compound 3, a percentage reported as inhibition, in the whole organism at one dose (the size of the read-out at that dose, not a potency): 0%
Estimate against measurement, compound 3: 60 percentage points above, outside the stated range (below it).
By their numbers in this assay, from the lowest: compound 3; then compound 1; then compound 2.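

The aromatic nitrogen, silent in the earlier aryl comparison, carries a substituent that matters in this assay: a number 60 percentage points lower from compound 1 to compound 3 (beyond the scatter), a large step set against the modest one at the aryl group, a number 20 percentage points higher from compound 1 to compound 2 (beyond the scatter). Thus ethyl on this nitrogen is compatible with inhibition at the dose given, whereas amino there is not, at least with the methyl-bearing aryl group. Nothing available explains this loss. Open, as far as these compounds go, is whether methyl or a longer chain such as propyl retains the inhibition seen with ethyl. Also open, from the compounds shown here alone, is whether amino has the same effect alongside the bromo of compound 2.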